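One Inverted Stereocentre, One Open Question

The source may report more compounds than this note shows. Statements on the series, on what has been measured and on what is new or still open speak of the compounds shown alone.

Among the compounds with values here, compound 1 `O=C(CCCCC[C@@H]1NC(=O)[C@H]2CCCN2C(=O)[C@@H]2CCCCCCCCCC[C@@H](NC1=O)C(=O)N2)NO` is assessed in an assay on HEK-293T cells for inhibition of protein deacetylase HDAC6 (Mus musculus), read by FLIPR, with a stated time of 30 min (on this read-out higher numbers stand for weaker inhibition and lower numbers for stronger inhibition), where compound 1 gives 410 nM, the higher of the two numbers measured so far. Its companion compound 2 `O=C(CCCCC[C@@H]1NC(=O)[C@H]2CCCN2C(=O)[C@@H]2CCOCCCCOCC[C@@H](NC1=O)C(=O)N2)NO` gives 240 nM in this assay, a gap that stays within the usual scatter, so neither compound stands apart. Compound 3 `O=C(CCCCC[C@@H]1NC(=O)[C@H]2CCCN2C(=O)[C@@H]2CCCCCCCCCC[C@H](NC1=O)C(=O)N2)NO` keeps every atom and bond of compound 1 and differs from it only in configuration as drawn: the two compounds have the same atoms and bonds and differ only in configuration as drawn: 1 of 4 stereo elements differ; a stereocentre at a saturated ring carbon is drawn R in compound 1 and S in compound 3. Within the data shown here, no measured pair shows what such an inversion does here. A loss beyond the scatter is expected, so the step of a 2.9-fold higher number from compound 1 to compound 3 (0.47 log units; beyond the scatter) is estimated. Compound 3 is expected to give 1200 nM, within 300 nM to 5000 nM.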

Compound 3, half-maximal inhibitory concentration: 230 nM
Estimate against measurement, compound 3: 5.2-fold (0.72 log units) above; measured number outside the range, below it.
By their numbers in this assay, from the lowest: compounds 3, 2 and 1 (each within the scatter of the next).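

At this saturated ring carbon, drawing the stereocentre S rather than R gives a 1.8-fold lower number from compound 1 to compound 3 (0.25 log units; within the scatter) in this assay, so on this read-out the inversion does not separate the two compounds. The earlier compounds shown here offered no pair isolating this change, whereas this comparison rests on a single difference: the fact that compounds 1 and 3 differ only in the configuration as drawn.

On these data alone, it remains open whether inverting any of the other three stereo elements would be tolerated in the same way. Also open, as far as these compounds go, is whether this inversion would read alike in compound 2, or with a carboxylic acid in place of the hydroxamic acid.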